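Hydroxypiperidinyl replacing the aryl ether on the shared core

The source may hold more compounds than are shown below. What is called first, only, known or untested is meant among the compounds shown, and "the series" means these compounds.

Of the compounds shown here, two have numbers so far. In a functional assay for inhibition of sodium/hydrogen exchanger (Oryctolagus cuniculus) (a higher number here means a weaker inhibitor, a lower number a stronger inhibitor), compound 1 `Cc1cc(-c2ccc(F)cc2)c(S(C)(=O)=O)cc1C(=O)N=C(N)N` gives 36 nM, and compound 2 `Cc1cc(Oc2cccc(Cl)c2)c(S(C)(=O)=O)cc1C(=O)N=C(N)N` gives 21 nM. Among the compounds with values here, the only measured step, a 1.7-fold lower number from compound 1 to compound 2 (0.23 log units; within the scatter), shows the two aryl groups on the shared core sitting within the scatter of each other. Compound 3 `Cc1cc(N2CCCC(O)C2)c(S(C)(=O)=O)cc1C(=O)N=C(N)N` brings (3-hydroxypiperidin-1-yl in place of 3-chlorophenoxy on an aromatic carbon). Within the data shown here, no measured step covers an exchange of an aromatic group for a saturated heterocycle at this position, so the one step at hand does not bear on it directly. The estimate for compound 3 in this assay is 80 nM, with a range of 20 nM to 400 nM, meaning an expected step of a 3.8-fold higher number from compound 2 to compound 3 (0.58 log units; beyond the scatter) and a wider range than the scatter.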

Compound 3, half-maximal inhibitory concentration: 30 nM
Beside the measured number, compound 3's estimate is 2.7-fold (0.43 log units) above it; measured number inside the range.
By their numbers in this assay, from the lowest: compounds 2, 3 and 1 (each within the scatter of the next).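

In this assay, this position takes a saturated ring as readily as an aromatic one, with 3-hydroxypiperidin-1-yl giving a 1.4-fold higher number from compound 2 to compound 3 (0.15 log units; within the scatter) against 3-chlorophenoxy and a 1.2-fold lower number from compound 1 to compound 3 (0.08 log units; within the scatter) against 4-fluorophenyl. Across these three compounds, then, an aromatic ring at this position is not required to keep the number in this range. Nothing available accounts for this result. The compounds shown leave open what the ring hydroxyl contributes, which unsubstituted piperidin-1-yl would test. Also open, going by these compounds, is whether an amine or a carboxylic acid in its place would keep the number in this range.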